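The compounds below may be only part of what the source reports. "The series", "measured", "known", "first", "only" and "open" are said of these compounds alone.

Three seleno-carbamates have been measured so far in a functional assay on PC-3 cells (Homo sapiens) for cytotoxicity, read by MTT assay, with a stated time of 72 h; on this read-out lower numbers stand for stronger inhibition of growth and higher numbers for weaker inhibition of growth. Compound 1, with the structure `CC(C)COC(=O)Nc1ccc([Se][Se]c2ccc(NC(=O)OCC(C)C)cc2)cc1`, gives 24200 nM. Compound 2, with the structure `N#C[Se]c1ccc(NC(=O)Oc2ccc(F)cc2)cc1`, gives 11800 nM. Compound 3, with the structure `C=CCOC(=O)Nc1ccc([Se]C#N)cc1`, gives 17600 nM. On these three numbers compound 3 sits between compound 1 and compound 2, and both of those neighbours lie within the usual scatter of repeated measurements, so the three compounds cannot be told apart on this read-out.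

The step of interest leads from compound 3 to compound 4, whose structure is `N#C[Se]c1ccc(NC(=O)OCc2ccccc2)cc1`. The counted difference is phenyl in place of vinyl on a saturated chain carbon bound to an oxygen next to a carbonyl group. Within the data shown here, no pair of measured compounds shows this change, so there is no measured step to lean on. Among the measured compounds shown here, the three numbers so far cluster closely even though the groups on the carbamate oxygen vary, which suggests that this part of the molecule does not move the result much. The step from compound 3 to compound 4 is therefore expected to be small, a 1.3-fold lower number from compound 3 to compound 4 (0.10 log units; within the scatter), most likely no larger than the scatter. Compound 4 is estimated to give 14000 nM in this assay, with a range from 5000 nM to 40000 nM.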

Compound 4, concentration for 50% growth inhibition: 3700 nM
Compound 4: middle estimate off by 3.8-fold (0.58 log units), on the high side; the whole stated range lies above it.
By their numbers in this assay, from the lowest: compound 4; then compounds 2, 3 and 1 (each within the scatter of the next, the first and the last beyond it).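

In this assay, among these compounds, putting phenyl in place of vinyl on a saturated chain carbon bound to an oxygen next to a carbonyl group gives a 4.8-fold lower number from compound 3 to compound 4 (0.68 log units; beyond the scatter), and this is the first step here in which only one place in the molecule changes. The earlier compounds shown here differ from one another in more than one place, so their close numbers could not show what this group does on its own; this single change shows that the group on the carbamate oxygen can move the number beyond the usual scatter. Nothing available explains the drop, so the result stands as an observation without a known cause.

On these data alone, this is one pair in one assay, so it remains open whether the gain belongs to the aromatic ring itself or would also appear with a cyclohexyl group or a longer chain in the same place. As far as these compounds go, it is equally open whether a methoxy group or a chlorine atom on the phenyl ring would lower the number further, leave it unchanged or raise it.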